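Second fluoro on the aryl ring of compound 2

This account rests on a few compounds, and the source may have more. Where it says the series, first, only, none or still open, it means among the compounds named here.

Measured so far:
compound 1, `C[C@H](O[C@H]1CC[C@]2(CC1)COC(C)(C)C2)c1nc(-c2ccc(CS(C)(=O)=O)c(F)c2)no1`: 430 nM
compound 2, `C[C@@H](O[C@H]1CC[C@]2(CC1)COC(C)(C)C2)c1nc(-c2ccc(CS(C)(=O)=O)c(F)c2)no1`: 27 nM

In a functional assay on HEK293 cells for agonist activity at Glucose-dependent insulinotropic receptor (Homo sapiens), read by cAMP accumulation, with a stated time of 30 min (a lower number here means that less compound is needed, a higher number that more compound is needed for the effect), compound 2 stands at the lower of the two numbers, with compound 1 the nearest comparator at a much higher value. Going by the values given here, the only measured step in this assay, a 16-fold lower number from compound 1 to compound 2 (1.20 log units; beyond the scatter), is a large one, and it rests entirely on (the fact that compounds 1 and 2 differ only in the configuration as drawn); the substitution on the aryl ring is identical in both, so no measured step speaks to changes on that ring.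

Compound 3, `C[C@@H](O[C@H]1CC[C@]2(CC1)COC(C)(C)C2)c1nc(-c2cc(F)c(CS(C)(=O)=O)cc2F)no1`, keeps the configuration of compound 2 and differs by fluoro in place of hydrogen on an aromatic carbon. Nothing measured bears directly on this change; the configurational step between compound 1 and compound 2 gives no guidance on how the added fluoro will read out. Among the compounds with values here, with no anchoring step, the working expectation is a number close to that of compound 2, with the estimated step of a 1.1-fold higher number from compound 2 to compound 3 (0.05 log units; within the scatter) set to lie within the scatter. Compound 3 is therefore estimated in this assay at 30 nM, with a range from 10 nM to 90 nM.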

Compound 3, half-maximal effective concentration: 64 nM
The estimate for compound 3 lay 2.1-fold (0.33 log units) below the measured number; the range from low to high includes it.
By their numbers in this assay, from the lowest: compound 2; then compound 3; then compound 1.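

In this assay, going by these compounds alone, fluoro in place of hydrogen gives a 2.4-fold higher number from compound 2 to compound 3 (0.37 log units; beyond the scatter), the first measured step on the aryl ring; it is modest but beyond the scatter. The position, ortho to a large group, meta to a (methylsulfonyl)methyl group and para to a fluoro group, therefore accepts a fluoro with a real but limited rise in the number, far smaller than the configurational step, a 16-fold lower number from compound 1 to compound 2 (1.20 log units; beyond the scatter). Nothing at hand accounts for the rise seen with this fluoro.

With only hydrogen and fluoro compared at this position, the compounds shown cannot tell whether the rise is particular to fluoro or would also appear with chloro, methyl, methoxy or a nitrile. They also leave open whether the same change would give a step of similar size in the configuration of compound 1, and whether the fluoro already on the ring in compound 2 contributes to the number at all, since no comparison with hydrogen in its place is available.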